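The source may hold more compounds than are shown below. What is called first, only, known or untested is meant among the compounds shown, and "the series" means these compounds.

Measured so far in a physicochemical assay for lipophilicity, measured as octanol-water partition, at pH 7.4; on this read-out lower numbers stand for lower lipophilicity and higher numbers for higher lipophilicity:
- compound 1 `Cc1ccc2[nH]c(C(=O)N[C@H]3CN(S(=O)(=O)c4ccccc4)C[C@@H]3C(=O)N[C@H]3CCCNC3)cc2c1`: 1.3
- compound 2 `O=C(N[C@H]1CN(S(=O)(=O)c2ccccc2)C[C@@H]1C(=O)N[C@H]1CCCNC1)c1cc(C2CC2)n[nH]1`: 0.2
- compound 3 `O=C(N[C@H]1CN(S(=O)(=O)c2ccccc2)C[C@@H]1C(=O)N[C@H]1CCCNC1)c1cc(-c2ccccc2)on1`: 1.3

Compound 3 stands level with compound 1, and both sit well above compound 2. Compound 4 `O=C(N[C@H]1CN(S(=O)(=O)c2ccccc2)C[C@@H]1C(=O)N[C@H]1CCCNC1)c1cc(-c2ccc(Cl)cc2Cl)on1` has not been measured yet. It carries 2,4-dichlorophenyl in place of phenyl on an aromatic carbon, next to the ring oxygen (2,4-dichlorophenyl in place of phenyl on an aromatic carbon).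

The measured steps each exchange the whole group on the carbonyl carbon. They include a number 1.10 log units lower from compound 1 to compound 2 (beyond the scatter) and a number 1.10 log units higher from compound 2 to compound 3 (beyond the scatter), but also no change at the digits printed from compound 1 to compound 3 (within the scatter). So a change in this part of the molecule can be large or can leave no visible mark in this assay. None of these steps adds chlorine to a phenyl, so they guide the size only loosely. The change here only adds to the group, and a rise of about the size of the large steps seems the likeliest outcome. The expected step is a number 1.00 log units higher from compound 3 to compound 4 (beyond the scatter). For compound 4 the estimated value is 2.3, with an expected range from 1.8 to 2.8.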

Compound 4, distribution coefficient: 2.5
Beside the measured number, compound 4's estimate is 0.20 log units below it; measured number inside the range.
By their numbers in this assay, from the lowest: compound 2; then compounds 1 and 3 (each within the scatter of the next); then compound 4.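

The earlier steps shown here each exchanged the whole group on the carbonyl carbon, whereas this one keeps the phenyl ring on its aromatic carbon, next to the ring oxygen, and only adds chlorine to it, giving a number 1.20 log units higher from compound 3 to compound 4 (beyond the scatter) in this assay. Adding two chlorine atoms to the phenyl therefore moves the number about as far as the whole-group exchange that gave a number 1.10 log units higher from compound 2 to compound 3 (beyond the scatter). No measurement shown here bears on why the number rises.

As far as these compounds go, with 2,4-dichlorophenyl as the only substituted phenyl at this position, the share of each chlorine stays unknown, since no phenyl with a single chlorine appears. From the compounds shown here alone, it also stays open how a phenyl carrying a methoxy group, an amine or a carboxylic acid would read in this assay.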